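Pyrimidin-5-yl for Pyridin-4-yl: Expected Metabolic Stability

The source may report more compounds than this note shows. Statements on the series, on what has been measured and on what is new or still open speak of the compounds shown alone.

Compound 1 `COc1ccccc1S(=O)(=O)/C=C/c1ccccn1` gives 91% in an ADME assay on microsomes from liver (Homo sapiens) for metabolic stability, read by LC-MS, using NADPH, with stated times of 5 min and 30 min, tested at 1 uM; on this read-out higher numbers stand for a more stable compound and lower numbers for a less stable compound.
Compound 2 `COc1ccccc1S(=O)(=O)/C=C/c1cccnc1` gives 97% in this assay.
Compound 3 `COc1ccccc1S(=O)(=O)/C=C/c1ccncc1` gives "not determined" (no result reported) in this assay.

Compound 3 stands nowhere on the numbers: no measurement was reported for it, so its place can only be guessed from compounds 1 and 2, which share its core and both remain largely intact, the step of a number 6 percentage points higher from compound 1 to compound 2 (within the scatter) lying within the scatter. Compound 4 `COc1ccccc1S(=O)(=O)/C=C/c1cncnc1` differs from compound 3 in one place: pyrimidin-5-yl in place of pyridin-4-yl on a double-bonded chain carbon bound to a double-bonded chain carbon. Going by the values given here, no measured step exchanges a pyridinyl for a pyrimidinyl ring; the single known step, a number 6 percentage points higher from compound 1 to compound 2 (within the scatter), bears on it only by showing that exchanging pyridin-2-yl for pyridin-3-yl did not move the read-out beyond the scatter. On that thin evidence, no step beyond the scatter is expected in this assay for compound 4. Compound 4 is therefore expected to give 90%, within 70% to 100%.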

Compound 4, percent of the compound remaining: 98%
Compound 4: the middle estimate sits 8 percentage points below what was measured, and the stated range covers the measured number.
By their numbers in this assay, from the lowest: compounds 1, 2 and 4 (each within the scatter of the next).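

Going by these compounds alone, the earlier compounds showed only one pyridinyl ring exchanged for another. At this place, on a double-bonded chain carbon bound to a double-bonded chain carbon, a ring with 2 hetero atoms now also stays within the scatter in this assay: pyrimidin-5-yl gives a number 1 percentage points higher from compound 2 to compound 4 (within the scatter) and a number 7 percentage points higher from compound 1 to compound 4 (within the scatter). No available evidence explains this result. All the rings shown at this place are six-membered and aromatic, so it stays open how an amine or a carboxylic acid there would fare in this assay.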